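Cytotoxicity notes on the piperidine ester series, next compound

A few compounds are considered here, and "the series" means these few. Any claim that something is new, unique, unknown or untested is made for them only; others in the source may bear on it.

Compound 1 `Cc1ncc([N+](=O)[O-])n1CCSC(=S)N1CCC(OC(=O)C(Cl)Cl)CC1` gives > 1000 ug/mL in an ADME assay on HeLa cells (Homo sapiens) for cytotoxicity; on this read-out lower numbers stand for stronger inhibition and higher numbers for weaker inhibition; this value is a limit of the assay, not a number.
Compound 2 `Cc1ncc([N+](=O)[O-])n1CCSC(=S)N1CCC(OC(=O)CCl)CC1` gives 930 ug/mL in this assay.
Compound 3 `Cc1ncc([N+](=O)[O-])n1CCSC(=S)N1CCC(C)CC1` gives 190 ug/mL in this assay.

Compound 3 stands lowest of the two numbers shown. Its nearest neighbour is compound 2, separated by a 4.9-fold lower number from compound 2 to compound 3 (0.69 log units; beyond the scatter), which lies beyond the scatter. Compound 1 sits at the limit (the limit of > 1000 ug/mL in this assay, at which 1 of the 3 values shown sits), so the step of an at least 5.2-fold lower number from compound 1 to compound 3 (0.72 log units; beyond the scatter) is known only as a floor.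

The next compound, compound 4 `CCOC(=O)C1CCN(C(=S)SCCn2c([N+](=O)[O-])cnc2C)CC1`, differs from compound 3 by ethoxycarbonyl in place of methyl on a saturated ring carbon.

Going by the values given here, two measured steps bear on this change, since both replace an oxygen-linked carbonyl-bearing group on the same saturated ring carbon with methyl: a 4.9-fold lower number from compound 2 to compound 3 (0.69 log units; beyond the scatter) and an at least 5.2-fold lower number from compound 1 to compound 3 (0.72 log units; beyond the scatter). Both lower the number. The change to compound 4 runs the other way, putting a carbonyl-bearing group back in place of methyl, so a rise in the number in this assay is expected, of roughly the size seen in those two steps. Neither precedent carries ethoxycarbonyl itself, and both carry chloro, so the expectation is tentative.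

Compound 4 is therefore expected to give about 600 ug/mL in this assay, within 250 ug/mL to 1000 ug/mL. The expected step is a 3.2-fold higher number from compound 3 to compound 4 (0.50 log units; beyond the scatter).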

Compound 4, half-maximal inhibitory concentration: 510 ug/mL
The estimate for compound 4 lay 1.2-fold (0.07 log units) above the measured number; the measured number falls inside the stated range.
By their numbers in this assay, from the lowest: compound 3; then compounds 4 and 2 (each within the scatter of the next). At a limit, above all of these: compound 1.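

The rise from methyl needs no chloro on the group: in this assay, the earlier rises both involved chlorinated groups, whereas ethoxycarbonyl, which carries no chlorine, gives a 2.7-fold higher number from compound 3 to compound 4 (0.43 log units; beyond the scatter). At this saturated ring carbon the data give a 1.8-fold lower number from compound 2 to compound 4 (0.26 log units; within the scatter) for ethoxycarbonyl against the chlorinated ester, so the two are not separated: a chloromethyl ester linked through oxygen and an ethyl ester linked through carbon read alike here, and compound 3 with its methyl remains the one clearly apart from both, as a 4.9-fold lower number from compound 2 to compound 3 (0.69 log units; beyond the scatter) and the rise above show. The step of an at least 1.9-fold lower number from compound 1 to compound 4 (0.29 log units; that floor lies within the scatter) is known only as a floor and cannot be read further. Compound 1 gives a limit of the assay and not a number: the limit of > 1000 ug/mL in this assay, at which 1 of the 4 values shown sits.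

Every group on this ring carbon that gives a higher number than methyl also carries a carbonyl, which leaves open whether the carbonyl or simply the larger group goes with the rise; a longer alkyl chain or an ether of similar length at the same place would separate the two. A carboxylic acid or an amide in place of the ethyl ester would show how far the ester itself matters.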